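Aryl-pyrazole acetonitriles: cytotoxicity on MOLT-4 cells

A few compounds are considered here, and "the series" means these few. Any claim that something is new, unique, unknown or untested is made for them only; others in the source may bear on it.

Compound 1 `COc1cc(C)cc(-c2c(-c3ccnc(-c4ccc(C(C)=O)cc4)c3)cnn2CC#N)c1`: > 100000 nM
Compound 2 `COc1cc(C)cc(-c2nn(CC#N)cc2-c2ccc(-c3cccc(C(C)=O)c3)nc2)c1`: > 100000 nM
Compound 3 `COc1cc(C)cc(-c2nn(CC#N)cc2-c2ccnc(-c3ccc(N(C)C)cc3)c2)c1`: > 100000 nM

In a functional assay on MOLT-4 cells (Homo sapiens) for inhibition, read by sulforhodamine B assay, with a stated time of 48 h (on this read-out lower numbers stand for higher toxicity in this test and higher numbers for lower toxicity in this test), compound 1 gives only a limit, > 100000 nM. Compound 2 likewise gives only a limit in this assay, > 100000 nM. Compound 3 also sits at the limit, > 100000 nM. All three values shown are limits, as noted in the limit of > 100000 nM in this assay, at which 3 of the 3 values shown sit, so compound 1 stands nowhere distinguishable from the others on these numbers. Compound 4 `COc1cc(C)cc(-c2c(-c3ccnc(-c4ccc(N(C)C)cc4)c3)cnn2CC#N)c1` is not yet measured; it differs from compound 1 by dimethylamino in place of acetyl on an aromatic carbon. Within the data shown here, no step between measured compounds is given. Given that compound 3, which also carries dimethylamino, shows > 100000 nM, no shift beyond the scatter is expected from compound 1 to compound 4 a step that the limit leaves unreadable from compound 1 to compound 4. Compound 4 is estimated at 200000 nM, between 80000 nM and 1000000 nM, most likely again reported as a limit.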

Compound 4, concentration lethal to 50% of the cells: > 100000 nM
Compound 4: a limit, no number; the forecaster's own chance of this, stated with the estimate: 85%; the middle value does not contradict the limit.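

Compound 1 and compound 4 each give only a limit in this assay, so no step between them can be read: the limit of > 100000 nM in this assay, at which 4 of the 4 values shown sit.

The compounds shown leave open which change to the shared core, if any, gives a readable value in this assay.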